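Swapping the Aryl Group: Expectation for Compound 4

A few compounds are considered here, and "the series" means these few. Any claim that something is new, unique, unknown or untested is made for them only; others in the source may bear on it.

Of the compounds shown here, three sharing one core have been measured in a functional assay on Ehrlich cells (Mus musculus) for cytotoxicity, tested at 100 ug/mL; on this read-out lower numbers stand for a weaker effect and higher numbers for a stronger effect at the one concentration tested. Compound 1 `COc1cc(N2C(N)=C(C#N)C(c3c(O)ccc4ccccc34)C3=C2CC(C)(C)CC3=O)cc(OC)c1OC` gives 90%. Compound 2 `COc1cc(N2C(N)=C(C#N)C(c3ccc(OC)c4ccccc34)C3=C2CC(C)(C)CC3=O)cc(OC)c1OC` gives 40%. Compound 3 `COc1cc(N2C(N)=C(C#N)C(c3cccc([N+](=O)[O-])c3)C3=C2CC(C)(C)CC3=O)cc(OC)c1OC` gives 30%, the lowest of the three numbers, though the gap to compound 2 is within the scatter while the gap to compound 1 is beyond it. Compound 4 `COc1ccccc1C1C(C#N)=C(N)N(c2cc(OC)c(OC)c(OC)c2)C2=C1C(=O)CC(C)(C)C2` has not been measured; it differs from compound 3 by 2-methoxyphenyl in place of 3-nitrophenyl on a saturated ring carbon. Going by the values given here, two steps bear on this change: a number 60 percentage points lower from compound 1 to compound 3 (beyond the scatter) was large, whereas a number 10 percentage points lower from compound 2 to compound 3 (within the scatter) stayed within the scatter, so a methoxy-bearing aryl group did not separate from the nitrophenyl one. Compound 4 is therefore expected to show a number 5 percentage points higher from compound 3 to compound 4 (within the scatter), no more than the scatter. The estimate for compound 4 in this assay is 35%, between 15% and 60%.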

Compound 4, a percentage reported as activity, at one concentration (the size of the read-out at that concentration, not a potency): 100%
The estimate for compound 4 lay 65 percentage points below the measured number, and the stated range ends below it.
By their numbers in this assay, from the lowest: compounds 3 and 2 (each within the scatter of the next); then compounds 1 and 4 (each within the scatter of the next).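

In this assay, putting 2-methoxyphenyl in place of 3-nitrophenyl on this saturated ring carbon gives a number 70 percentage points higher from compound 3 to compound 4 (beyond the scatter), so a high number here does not need the two-ring 2-hydroxynaphthalen-1-yl group. A methoxy-bearing aryl group is also not tied to a low number, since the change from 4-methoxynaphthalen-1-yl gives a number 60 percentage points higher from compound 2 to compound 4 (beyond the scatter), while the change from 2-hydroxynaphthalen-1-yl gives a number 10 percentage points higher from compound 1 to compound 4 (within the scatter). No evidence available here explains these differences.

Going by these compounds, it remains open what a plain phenyl group would give at this carbon. The same holds for a phenyl group carrying a dimethylamino group or a carboxylic acid.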